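The compounds below may be only part of what the source reports. "The series", "measured", "known", "first", "only" and "open" are said of these compounds alone.

Measured compounds:
Compound 1, `Cc1cc(C)cc(S(=O)(=O)n2c(SCC(=O)Nc3ccccc3Cl)nc3ccccc32)c1` — 107000 nM
Compound 2, `Cc1cc(C)cc(S(=O)(=O)n2c(SCC(=O)Nc3ccccc3Cl)nc3ccc(Cl)cc32)c1` — 99300 nM
Compound 3, `Cc1cc(C)cc(Cn2c(SCC(=O)Nc3ccc(C)cc3Cl)nc3ccccc32)c1` — 49200 nM

All three were tested in an ADME assay on MT4 cells (Homo sapiens) for cytotoxicity; a lower number here means that less compound is tolerated, a higher number that more compound is tolerated. Compound 1 gives 107000 nM and compound 2 gives 99300 nM. For the measured compounds named here, the one change between them is chloro in place of hydrogen on an aromatic carbon and it made a 1.1-fold lower number from compound 1 to compound 2 (0.03 log units; within the scatter). Compound 3, with a different core, gives 49200 nM; the difference between the core of compound 3 and the core of compound 1 is not broken down here. The number for compound 3 is lower than that for compound 1 by a margin beyond the scatter, while it and the number for compound 2 lie within the scatter of each other, so no order is drawn between those two.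

Compound 4, `Cc1cc(C)cc(Cn2c(SCC(=O)Nc3ccc(C)cc3Cl)nc3ccc(Cl)cc32)c1`, has not yet been measured in this assay. It differs from compound 3 by chloro in place of hydrogen on an aromatic carbon, the same change already seen from compound 1 to compound 2, where the place of the entering group is described in the same words. The expectation for compound 4 is therefore a 1.1-fold lower number from compound 3 to compound 4 (0.04 log units; within the scatter), an estimated step of about the size seen in a 1.1-fold lower number from compound 1 to compound 2 (0.03 log units; within the scatter), resting on that single earlier step in this assay and on the value of compound 3, 49200 nM. Going by the values given here, with only one prior example, the range is kept wide. Compound 4 is thus expected to give about 45000 nM, estimated to lie between 20000 nM and 100000 nM.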

Compound 4, half-maximal cytotoxic concentration: 79300 nM
Compound 4: middle estimate off by 1.8-fold (0.25 log units), on the low side; the measured number falls inside the stated range.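

In this assay, for the compounds shown here, chloro in place of hydrogen on an aromatic carbon of the fused system gave a 1.6-fold higher number from compound 3 to compound 4 (0.21 log units; within the scatter), so on this core, as on the core of compound 1, the change produced no step that stands clear of the scatter. Set side by side, the two steps cannot be told apart: the same change on two cores in this assay, a 1.1-fold lower number (0.03 log units; within the scatter) from compound 1 to compound 2 and a 1.6-fold higher number (0.21 log units; within the scatter) from compound 3 to compound 4, 1.7-fold (0.24 log units) apart, within the scatter of two such steps. This shows that, on these two cores, the change carried over as a step too small to read in this cell assay, but it does not show that the change has no effect in general, and the opposite directions of the two small steps cannot be taken as a real reversal between the cores, since two pairs within the scatter support no such reading.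

The compounds shown leave open whether a different group at the same aromatic carbon, such as a methoxy group, an amine or a carboxylic acid, would give a step beyond the scatter. They also leave open whether chloro at this place would give an equally small step on any core other than these two.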